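This account rests on a few compounds, and the source may have more. Where it says the series, first, only, none or still open, it means among the compounds named here.

Three close relatives have been tested in a functional assay on SNB-75 cells (Homo sapiens) for cytotoxicity, read by sulforhodamine B assay, with a stated time of 48 h; on this read-out lower numbers stand for higher toxicity in this test and higher numbers for lower toxicity in this test. Compound 3 `ClCc1ccc(Cn2cnc3c(Cl)nc(Cl)nc32)cc1` gives 45700 nM. Compound 2 `ClCc1cccc(Cn2cnc3c(Cl)nc(Cl)nc32)c1` is built from the same atoms joined differently; the difference between the two cores is not broken down here. In this assay compound 2 gives 7410 nM, the lowest number among the measured compounds. Compound 1 `Nc1nc(Cl)c2ncn(Cc3ccc(CCl)cc3)c2n1` is compound 3 with one change: amino in place of chloro on an aromatic carbon. For compound 1 the assay reports only a limit, > 100000 nM. That single change produced an at least 2.1-fold higher number from compound 3 to compound 1 (0.34 log units; beyond the scatter), a step whose full size stays hidden because one end sits at the limit of > 100000 nM in this assay, at which 1 of the 3 values shown sits.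

Compound 4 `Nc1nc(Cl)c2ncn(Cc3cccc(CCl)c3)c2n1` is compound 2 carrying the same change, made at the same place: amino in place of chloro on an aromatic carbon. Compound 4 is expected to move by a 4.0-fold higher number from compound 2 to compound 4 (0.61 log units; beyond the scatter), toward lower toxicity. That expectation rests on the step from compound 3 to compound 1, an at least 2.1-fold higher number from compound 3 to compound 1 (0.34 log units; beyond the scatter), applied to the starting value of compound 2, 7410 nM. Compound 4 is therefore estimated at 30000 nM, with a likely range from 12000 nM to 100000 nM, and some chance that the assay returns only a limit.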

Compound 4, concentration lethal to 50% of the cells: 51300 nM
Compound 4: middle estimate off by 1.7-fold (0.23 log units), on the low side; the measured number falls inside the stated range.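

In this assay, amino in place of chloro on an aromatic carbon of the core of compound 2 gave a 6.9-fold higher number from compound 2 to compound 4 (0.84 log units; beyond the scatter), so the number rose on this core as it did on the core of compound 3, toward lower toxicity in this test. The direction of the change therefore carried over between these two cores, but two pairs are a small base for any rule, and they do not establish that the size of the step carries over as well: the same change on two cores in this assay, an at least 2.1-fold higher number (0.34 log units; beyond the scatter) from compound 3 to compound 1 and a 6.9-fold higher number (0.84 log units; beyond the scatter) from compound 2 to compound 4; the limit leaves it open whether they differ Compound 1 is reported only as a limit, > 100000 nM.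

The compounds shown leave open whether a different group on that same aromatic carbon, such as a methylamino group, a methoxy group or a hydroxyl group, would shift the number in the same direction. They also leave open whether the same change would hold on cores beyond these two.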